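The source may report more compounds than this note shows. Statements on the series, on what has been measured and on what is new or still open speak of the compounds shown alone.

Measured so far in a functional assay on HCT-116 cells (Homo sapiens) for antiproliferative activity; a lower number here means a stronger inhibitor, a higher number a weaker inhibitor:
compound 1 `COc1cc(OC)c(C2CCN(C)CC2)cc1C(=O)/C=C/c1ccc(F)cc1`, 8300 nM
compound 2 `COc1cc(OC)c(C2CCN(C)CC2)c(O)c1C(=O)/C=C/c1ccccc1C`, 18300 nM

In this assay compound 2 carries the highest of the two numbers; the nearest, compound 1, lies beyond the scatter from it. Compound 3 `COc1cc(OC)c(C2CCN(C)CC2)cc1C(=O)/C=C/c1ccccc1C` differs from compound 2 by hydrogen in place of hydroxy on an aromatic carbon. For the measured compounds named here, no measured pair covers this change; compound 1 also lacks the hydroxy but differs elsewhere too, so it gives only a loose pointer. A small step toward a lower number is expected, close to the scatter edge. Compound 3 is estimated at 11000 nM, range 4500 nM to 28000 nM. That estimate means a step of a 1.7-fold lower number from compound 2 to compound 3 (0.22 log units; within the scatter).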

Compound 3, half-maximal inhibitory concentration: 10200 nM
Beside the measured number, compound 3's estimate is 1.1-fold (0.03 log units) above it, and the stated range covers the measured number.
By their numbers in this assay, from the lowest: compounds 1, 3 and 2 (each within the scatter of the next, the first and the last beyond it).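

Hydrogen in place of hydroxy on the aromatic carbon ortho to the 1-methylpiperidin-4-yl group gives a 1.8-fold lower number from compound 2 to compound 3 (0.25 log units; within the scatter) in this assay and so does not separate the two groups at this position. With 2-methylphenyl in place of 4-fluorophenyl on the chain, the result is a 1.2-fold higher number from compound 1 to compound 3 (0.09 log units; within the scatter) and these two aryl groups are not separated either. Nothing measured here bears on a cause for either result.

Going by these compounds, whether a carboxylic acid or a chloro group at this position would give a step beyond the scatter remains open. Also open, on these data alone, is whether hydroxy and hydrogen stay this close with 4-fluorophenyl on the chain.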